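Ethoxy in Place of Cyclohexyl on an Acylguanidine Core

The source may hold more compounds than are shown below. What is called first, only, known or untested is meant among the compounds shown, and "the series" means these compounds.

Compound 1 `CS(=O)(=O)c1cc(C(=O)N=C(N)N)c(Cl)cc1Cl`: 140 nM
Compound 2 `Cc1cc(C2CCCCC2)c(S(C)(=O)=O)cc1C(=O)N=C(N)N`: 22 nM

Of the compounds shown here, two have been measured in a functional assay for inhibition of sodium/hydrogen exchanger (Oryctolagus cuniculus); on this read-out higher numbers stand for weaker inhibition and lower numbers for stronger inhibition. In this assay compound 2 gives 22 nM, the lowest of the two numbers. Compound 1 gives 140 nM, a higher number that lies beyond the scatter, so compound 2 stands as the stronger inhibitor of the pair.

Compound 3 `CCOc1cc(C)c(C(=O)N=C(N)N)cc1S(C)(=O)=O` has not yet been measured. It differs from compound 2 in one place: ethoxy in place of cyclohexyl on an aromatic carbon. The group that leaves carries a ring, the group that enters is a short chain with one hydrogen-bond acceptor, and it sits ortho to the methylsulfonyl group.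

Among the measured compounds shown here, no measured pair shows this exact change, so the direction must be judged from the structures alone. In this assay the expected step is a 2.7-fold higher number from compound 2 to compound 3 (0.44 log units; beyond the scatter), a move toward weaker inhibition. Compound 3 is therefore estimated at 60 nM, within a range from 20 nM to 200 nM.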

Compound 3, half-maximal inhibitory concentration: 19 nM
Beside the measured number, compound 3's estimate is 3.2-fold (0.50 log units) above it; the whole stated range lies above it.
By their numbers in this assay, from the lowest: compounds 3 and 2 (each within the scatter of the next); then compound 1.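

In this assay, among the compounds shown here, the change from cyclohexyl to ethoxy on this aromatic carbon, ortho to a methylsulfonyl group, is a 1.2-fold lower number from compound 2 to compound 3 (0.06 log units; within the scatter) and so gives no step that can be told from the scatter. This shows that a six-membered non-aromatic ring of carbon only is not required at this place for a number in this range: ethoxy, with three heavy atoms, no ring and one hydrogen-bond acceptor, leaves compound 3 within the scatter of compound 2. Nothing measured here explains why two groups this different give such similar numbers.

The compounds shown leave open whether a plain ethyl group, without the oxygen, or a longer chain such as butoxy would keep the number close to that of compound 3. They also leave open how an amine or a carboxylic acid would fare on this same aromatic carbon, and so how widely this position accepts groups other than cyclohexyl and ethoxy.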